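The compounds below may be only part of what the source reports. "The series", "measured", "known", "first", "only" and "open" are said of these compounds alone.

Compound 1, `C#CCNCc1cn(-c2cc(NC(=S)NCC)ncn2)cn1`, gives 4330 nM in an assay on isolated protein for inhibition of Amine oxidase [flavin-containing] A (Homo sapiens), read by fluorescence and Amplex Red, with a stated time of 15 min; a higher number here means a weaker inhibitor, a lower number a stronger inhibitor.
Compound 2, `C#CCN(CC)Cc1cn(-c2cc(NC(=S)NCC)ncn2)cn1`, reaches only a limit of the assay in this assay, > 50000 nM.
Compound 3, `C#CCN(CCCC)Cc1cn(-c2cc(NC(=S)NCC)ncn2)cn1`, likewise reaches only a limit in this assay, > 50000 nM.

Compound 3 therefore has no number of its own, only a limit, and one further value shown is also a limit; how it compares with compound 2 cannot be read, because of the limit of > 50000 nM in this assay, at which 2 of the 3 values shown sit. Among the measured compounds shown here, its standing relative to the one numbered value is clear, though: an at least 11-fold higher number from compound 1 to compound 3 (1.06 log units; beyond the scatter), and the parallel change an at least 11-fold higher number from compound 1 to compound 2 (1.06 log units; beyond the scatter) points the same way. Compound 4, `C#CCN(CC#N)Cc1cn(-c2cc(NC(=S)NCC)ncn2)cn1`, differs from compound 3 by cyano in place of propyl on a saturated chain carbon bound to an amine nitrogen; cut one bond further out, the same difference reads butyl to cyanomethyl. The two readable steps both show that putting a carbon chain in place of the hydrogen on the amine nitrogen costs heavily, while the step that the two limits leave unreadable from compound 2 to compound 3 leaves the length of that chain unreadable. Compound 4 still carries a carbon on that nitrogen, so it is expected to stay in the weak region, with the step of an at least 1.2-fold lower number from compound 3 to compound 4 (0.09 log units; that floor lies within the scatter), because the measured steps of an at least 11-fold higher number from compound 1 to compound 2 (1.06 log units; beyond the scatter) and an at least 11-fold higher number from compound 1 to compound 3 (1.06 log units; beyond the scatter) both went the same way. The estimate for compound 4 is 40000 nM, within 8000 nM to 200000 nM, and a limit rather than a number remains the more likely outcome.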

Compound 4, half-maximal inhibitory concentration: > 50000 nM
Compound 4: no number, only a limit (the forecaster's own chance of this, stated with the estimate: 60%); at least 1.2-fold (0.09 log units) between middle value and limit.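

In this assay compound 4 reaches only a limit of the assay, > 50000 nM. The earlier losses came from plain carbon chains on the amine nitrogen, whereas cyanomethyl ends in a nitrile, which brings a hydrogen-bond acceptor that propyl lacks, and the loss is still there: an at least 11-fold higher number from compound 1 to compound 4 (1.06 log units; beyond the scatter). So among the compounds shown, all three groups placed on this nitrogen in place of hydrogen give a large step up in the number, and none goes against this, but the steps linking compound 2, compound 3 and compound 4 cannot be read, and no order among ethyl, butyl and cyanomethyl can be given, because these compounds share one limit: the limit of > 50000 nM in this assay, at which 3 of the 4 values shown sit.

On these data alone, what stays open is whether a group smaller than ethyl, such as methyl, would keep a measurable value on this nitrogen, or whether only the hydrogen of compound 1 does. As far as these compounds go, it is also open whether a chain ending in a hydroxyl or a carboxylic acid would fare any differently from the nitrile.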